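Opening the lactone ring into a diethyl acetal

The source may hold more compounds than are shown below. What is called first, only, known or untested is meant among the compounds shown, and "the series" means these compounds.

Measured so far in an assay on microsomes from liver for inhibition of sterol O-acyltransferase 1 (Rattus norvegicus); a higher number here means a weaker inhibitor, a lower number a stronger inhibitor:
Compound 1 `C[C@]1(O)CC(=O)OC(CSc2nc(-c3ccccc3)c(-c3ccccc3)[nH]2)C1` gives 140 nM.
Compound 2 `Cc1ccc(-c2nc(SC[C@H]3C[C@@](C)(O)CC(=O)O3)[nH]c2-c2ccc(C)cc2)cc1.Cc1ccc(-c2nc(SC[C@H]3C[C@](C)(O)CC(=O)O3)[nH]c2-c2ccc(C)cc2)cc1` gives 170 nM.
Compound 3 `CC1=CC(=O)OC(CSc2nc(-c3ccccc3Cl)c(-c3ccccc3Cl)[nH]2)C1` gives 1700 nM.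

Compound 1 has the lowest of the three numbers in this assay. Compound 2 sits so close to it that the two cannot be told apart within the usual scatter of this kind of measurement. Compound 3 stands clearly apart, with a number beyond the scatter above compound 1, though it differs from compound 1 in more than one place, so no single cause can be read from that gap.

The next compound, compound 4 `CCOC(CCSc1nc(-c2ccccc2)c(-c2ccccc2)[nH]1)OCC`, differs from compound 1 in one place: a group of 8 heavy atoms (6 carbon, 2 oxygen; no ring) in place of a group of 9 heavy atoms (6 carbon, 3 oxygen; one six-membered non-aromatic ring with 1 hetero atom), on a saturated chain carbon bound to a sulfur. The ring that carries the hydrogen-bond donor is gone, and an open chain of two ethoxy groups takes its place.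

For the measured compounds named here, no measured pair isolates this exchange. Compound 3, which also lacks the hydroxylated saturated ring, gives 1700 nM. On that basis the expectation is a step toward a weaker inhibitor, a 5.7-fold higher number from compound 1 to compound 4 (0.76 log units; beyond the scatter), beyond the scatter. Compound 4 is therefore estimated at 800 nM, with a plausible range from 200 nM to 4000 nM.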

Compound 4, half-maximal inhibitory concentration: 69 nM
Compound 4: the middle estimate sits 12-fold (1.06 log units) above what was measured, outside the stated range (below it).
By their numbers in this assay, from the lowest: compound 4; then compounds 1 and 2 (each within the scatter of the next); then compound 3.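

Compounds 1, 2 and 3 all carry a six-membered ring at this place, so none of them could show what happens without one. In this assay the open 2,2-diethoxyethyl group gives a 2.0-fold lower number from compound 1 to compound 4 (0.31 log units; beyond the scatter) and this modest step lies beyond the scatter, so on this saturated chain carbon bound to a sulfur, neither the ring, its hydrogen-bond donor nor its defined stereocentre is needed for inhibition with this shared core. Nothing measured here explains the gain.

The exchange removes all three features at once, so the compounds shown cannot tell which of them counts on its own, or what the ethoxy groups themselves contribute. As far as these compounds go, how a carboxylic acid, an amine or a longer chain at this place would compare also stays open.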